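From a propenyl amide to a chlorobutyl amide

This account rests on a few compounds, and the source may have more. Where it says the series, first, only, none or still open, it means among the compounds named here.

Measured so far in a functional assay on HCT-116 cells (Homo sapiens) for inhibition, read by MTT assay, with a stated time of 48 h (a higher number here means a weaker inhibitor, a lower number a stronger inhibitor), as follows
- compound 1 `COc1ccc(CN(C(=O)C(C)Br)c2cc(OC)c(OC)c(OC)c2)cc1O` gives 140 nM here
- compound 2 `CCC/C=C/C(=O)N(Cc1ccc(OC)c(O)c1)c1cc(OC)c(OC)c(OC)c1` gives 95 nM here
- compound 3 `C/C=C/C(=O)N(Cc1ccc(OC)c(O)c1)c1cc(OC)c(OC)c(OC)c1` gives 55 nM here

Compound 3 cannot be told apart from compound 2 on these numbers, but it stands clear of compound 1. The two steps read a 1.7-fold lower number from compound 2 to compound 3 (0.24 log units; within the scatter) and a 2.5-fold lower number from compound 1 to compound 3 (0.41 log units; beyond the scatter) on this scale.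

Compound 4 `COc1ccc(CN(C(=O)CCCCCl)c2cc(OC)c(OC)c(OC)c2)cc1O` comes next, with 4-chlorobutyl in place of prop-1-en-1-yl on a carbonyl carbon, counted as 4-chlorobutyl in place of prop-1-en-1-yl on a carbonyl carbon for this change. Within the data shown here, no measured compound carries 4-chlorobutyl. The closest guide is the swap of 1-bromoethyl for prop-1-en-1-yl, seen as a 2.5-fold lower number from compound 1 to compound 3 (0.41 log units; beyond the scatter) here, and read backwards it points to a higher number. The swap to pent-1-en-1-yl gave only a 1.5-fold lower number from compound 1 to compound 2 (0.17 log units; within the scatter) in the same direction, so the expected size is modest and uncertain. In this assay the expected change is a 2.4-fold higher number from compound 3 to compound 4 (0.37 log units; beyond the scatter) overall. Compound 4 is expected at 130 nM as a middle value, with an estimated range from 45 nM to 400 nM around it.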

Compound 4, half-maximal inhibitory concentration: 220 nM
For compound 4 the middle estimate is 1.7-fold (0.23 log units) below the measured one, within the range that was stated.
By their numbers in this assay, from the lowest: compounds 3, 2, 1 and 4 (each within the scatter of the next, the first and the last beyond it).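

In this assay, among these compounds, 4-chlorobutyl on a carbonyl carbon is the first group here to stand clear of both prop-1-en-1-yl and pent-1-en-1-yl, with a 4.0-fold higher number from compound 3 to compound 4 (0.60 log units; beyond the scatter) and a 2.3-fold higher number from compound 2 to compound 4 (0.36 log units; beyond the scatter) both beyond the scatter, whereas 1-bromoethyl stood clear only of prop-1-en-1-yl. The two halogen-bearing groups cannot be told apart, with a 1.6-fold higher number from compound 1 to compound 4 (0.20 log units; within the scatter) within the scatter, but this is no clean split between them and the chains with a double bond, and compound 2 goes against such a split, as it too cannot be told apart from compound 1. No measurement shown offers an explanation for these differences.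

The compounds shown leave open whether the higher number goes with the chlorine or with the saturated chain, and a plain butyl chain at this place would separate the two. They also leave open how a chain carrying an amine or a carboxylic acid would read.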